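The compounds below may be only part of what the source reports. "The series", "measured", "known", "first", "only" and "open" are said of these compounds alone.

Measured compounds in this study:

compound 1 `ClCc1ccccc1Cn1cnc2c(Cl)nc(Cl)nc21` — > 100000 nM
compound 2 `ClCc1ccccc1Cn1cnc2c(Cl)ncnc21` — > 100000 nM
compound 3 `ClCc1ccc(Cn2cnc3nc(Cl)nc(Cl)c32)cc1` — 83200 nM

All three were tested in a functional assay on MCF7 cells (Homo sapiens) for cytotoxicity, read by sulforhodamine B assay, with a stated time of 48 h; on this read-out higher numbers stand for lower toxicity in this test and lower numbers for higher toxicity in this test. Compound 1 gave only a limit of the assay, > 100000 nM, and not a number. Compound 2 likewise gave only a limit, > 100000 nM. Going by the values given here, compound 3 is the one compound for which a number is available, 83200 nM. This number sits not far from the level at which the other two values stand, (the limit of > 100000 nM in this assay, at which 2 of the 3 values shown sit).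

Compound 2 differs from compound 1 by a single change, (hydrogen in place of chloro on an aromatic carbon). Because both values are limits, the step that the two limits leave unreadable from compound 1 to compound 2 cannot be read: it may be small or large, and the data cannot say which.

Compound 3 has the same atoms as compound 1, joined differently; the difference between the two cores is not broken down here.

Compound 4 `ClCc1ccc(Cn2cnc3ncnc(Cl)c32)cc1` has not yet been measured. It stands to compound 3 as compound 2 stands to compound 1: the change is hydrogen in place of chloro on an aromatic carbon, and its surroundings are described in the same words as for the earlier pair, so this is the same change made on the other core. In this assay the expected step from compound 3 to compound 4 is a 1.3-fold higher number from compound 3 to compound 4 (0.12 log units; within the scatter); this rests on the value of compound 3, 83200 nM, and on the fact that the earlier step that the two limits leave unreadable from compound 1 to compound 2 gives no readable size, so no shift can be predicted. Compound 4 is therefore estimated at 110000 nM, with a plausible span from 50000 nM to 250000 nM, and a real chance that this assay again returns only a limit.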

Compound 4, concentration lethal to 50% of the cells: 6450 nM
Beside the measured number, compound 4's estimate is 17-fold (1.23 log units) above it; measured number outside the range, below it.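

In this assay, putting hydrogen in place of the chloro group that sits between two ring nitrogen atoms gives a 13-fold lower number from compound 3 to compound 4 (1.11 log units; beyond the scatter), so on the core of compound 3 this single change goes with clearly higher toxicity in this test. This is one measured pair on one core, and it shows that the change can matter a great deal there, but not that it will do the same on any other core in the series. The same change on the core of compound 1 cannot be read, so the data neither support nor contradict a shared effect on the two cores, and both compounds of that earlier pair give a limit of the assay rather than a number: the limit of > 100000 nM in this assay, at which 2 of the 4 values shown sit.

The compounds shown leave open what other groups at this same place would do, such as an amine or a methoxy group, and so whether hydrogen is special there or the loss of chloro alone goes with the lower number. They also leave open how far the chloromethyl group on the benzene ring contributes to the number of compound 4, which a comparison with a compound carrying a plain methyl group or a longer chain in its place could address.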